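The source may hold more compounds than are shown below. What is called first, only, known or untested is meant among the compounds shown, and "the series" means these compounds.

Compound 1 `CCc1ccc(Nc2cc(NC(=O)Nc3c(Cl)cccc3Cl)ncn2)cc1`: 58%
Compound 2 `CCc1cccc(Nc2cc(NC(=O)Nc3cc(OC)cc(OC)c3)ncn2)c1`: 52.6%
Compound 3 `COc1cc(Nc2cc(NC(=O)Nc3c(Cl)cccc3Cl)ncn2)cc(OC)c1`: 73.7%

In a functional assay on HCC827 cells (Homo sapiens) for inhibition, read by MTT assay, with a stated time of 48 h, tested at 10 uM (a higher number here means more inhibition at the concentration tested (going by the name of the read-out), a lower number less inhibition), compound 2 gives 52.6%, the lowest of the three numbers. Compound 1 lies within the scatter of compound 2, while compound 3 lies beyond it. Compound 4 `COc1cc(NC(=O)Nc2cc(Nc3cc(F)ccc3OC)ncn2)cc(OC)c1` has not been measured yet. It differs from compound 2 in a single place: 5-fluoro-2-methoxyphenyl in place of 3-ethylphenyl on a nitrogen on an aromatic ring. Among the measured compounds shown here, no pair of measured compounds differing in one place is available, so no step size for such a swap is known here. Given the narrow spread among the measured compounds, a step within the scatter, in either direction, is expected. Compound 4 is thus estimated at 58%, in a range from 40% to 76%. The expected step of a number 5.4 percentage points higher from compound 2 to compound 4 (within the scatter) stays within the scatter.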

Compound 4, a percentage reported as inhibition, at one concentration (the size of the read-out at that concentration, not a potency): 59%
Compound 4: middle estimate off by 1 percentage points, on the low side; the measured number falls inside the stated range.
By their numbers in this assay, from the lowest: compounds 2, 1 and 4 (each within the scatter of the next); then compound 3.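

In this assay, placing 5-fluoro-2-methoxyphenyl instead of 3-ethylphenyl on the nitrogen gives a number 6.4 percentage points higher from compound 2 to compound 4 (within the scatter) at the single concentration tested. The number is therefore level across this swap of one substituted phenyl for another, even though the entering group adds a hydrogen-bond acceptor. No available measurement explains this result. The compounds shown leave open how the fluorine and the methoxy group would each behave alone. They also leave open how a ring bearing an amine or a carboxylic acid would behave at this nitrogen.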